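This account rests on a few compounds, and the source may have more. Where it says the series, first, only, none or still open, it means among the compounds named here.

Compound 1 `CCC1=C(O)c2c(oc(-c3ccc(OC)cc3)cc2=O)C(CC)(CC)C1=O` is the reference point of this set. Among the compounds with values here, in a functional assay on KB cells (Homo sapiens) for antiproliferative activity, read by sulforhodamine B assay, with a stated time of 3 days (on this read-out lower numbers stand for an effect already at smaller amounts and higher numbers for an effect only at larger amounts of compound), compound 1 gives 17.7 uM, the lowest of the three numbers measured so far. Compound 2 `CCC1=C(O)c2c(oc(-c3ccc(F)cc3)cc2=O)C(CC)(CC)C1=O` gives 33 uM in this assay, and compound 3 `CCC1=C(O)c2c(oc(-c3ccccc3C(F)(F)F)cc2=O)C(CC)(CC)C1=O` gives 45.6 uM; the gap from compound 1 to compound 3 lies beyond the scatter, whereas compound 2 sits within it. Within the data shown here, the only single-point step measured is a 1.9-fold higher number from compound 1 to compound 2 (0.27 log units; within the scatter).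

Compound 4 `CCC1=C(O)c2c(oc(-c3ccc(C)c(C)c3)cc2=O)C(CC)(CC)C1=O` is not yet measured. It differs from compound 1 by one exchange on the aryl substituent: 3,4-dimethylphenyl in place of 4-methoxyphenyl on an aromatic carbon. Among the measured compounds shown here, the one measured step that bears on this exchange is the step from compound 1 to compound 2, which also replaced the methoxy group on the same aryl ring and stayed within the scatter. For the measured compounds named here, compound 3 carries a trifluoromethyl group instead, and its number is higher than that of compound 1, but no single-point step connects it to compound 1, so it serves only as a loose indication that other aryl substituents do not drive the number downward. For compound 4 the expected outcome in this assay is therefore a 1.2-fold higher number from compound 1 to compound 4 (0.09 log units; within the scatter), that is, nothing beyond the scatter, leaning if anything toward a slightly higher number. The estimate for compound 4 is 22 uM, with a range from 10 uM to 50 uM.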

Compound 4, concentration for half-maximal effect: 35.5 uM
Compound 4: the middle estimate sits 1.6-fold (0.21 log units) below what was measured; the measured number falls inside the stated range.
By their numbers in this assay, from the lowest: compounds 1, 2, 4 and 3 (each within the scatter of the next, the first and the last beyond it).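

Measured in this assay the exchange of 4-methoxyphenyl for 3,4-dimethylphenyl gives a 2.0-fold higher number from compound 1 to compound 4 (0.30 log units; within the scatter) and joins the earlier 1.9-fold higher number from compound 1 to compound 2 (0.27 log units; within the scatter) as a second replacement at this position that stays within the scatter. The entering group has no hydrogen-bond acceptor, unlike 4-methoxyphenyl, and the number still does not move beyond the scatter in this step, while the new compound also links to the fluoro analogue through a 1.1-fold higher number from compound 2 to compound 4 (0.03 log units; within the scatter) so that 4-fluorophenyl and 3,4-dimethylphenyl cannot be told apart in this assay. No supporting measurement is available to explain these numbers.

Still open, going by these compounds, is whether any group on this aryl ring can move the number beyond the scatter in either direction, as an amine, a carboxylic acid or a longer alkoxy chain in place of methoxy might show. Also open, on these data alone, is how far the number depends on the rest of the shared core, which all four compounds carry unchanged.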